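Methoxycarbonyl for methoxymethyl on the furan-bearing core

The source may report more compounds than this note shows. Statements on the series, on what has been measured and on what is new or still open speak of the compounds shown alone.

Of the compounds shown here, three sharing one core have been measured in a functional assay on ZR-75-1 cells (Homo sapiens) for cytotoxicity, read by sulforhodamine B assay, with a stated time of 3 days; on this read-out higher numbers stand for an effect only at larger amounts of compound and lower numbers for an effect already at smaller amounts. Compound 1 `COCc1c(C)coc1-c1ccc2c(c1OC)CCCC2(C)C` gives 14.3 uM in this assay. Compound 2 `CCOc1c(-c2occ(C)c2CO)ccc2c1CCCC2(C)C` gives 14.3 uM, level with compound 1 at the digits recorded. Compound 3 `Cc1coc(-c2ccc3c(c2O)CCCC3)c1C(=O)O` gives 21.7 uM; its gap to compound 1 is within the scatter, so the three numbers are not told apart. Compound 4 `COC(=O)c1c(C)coc1-c1ccc2c(c1OC)CCCC2(C)C` has not yet been measured. It differs from compound 1 in one place: methoxycarbonyl in place of methoxymethyl on an aromatic carbon. For the measured compounds named here, no pair differing in a single place has been measured, so the size of this step cannot be read from the data. With all three measured values within the scatter of each other, no change beyond the scatter is expected for a 1.0-fold higher number from compound 1 to compound 4 (0.02 log units; within the scatter). Compound 4 is therefore estimated at 15 uM in this assay, within 6 uM to 40 uM.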

Compound 4, concentration for half-maximal effect: 34.5 uM
The estimate for compound 4 lay 2.3-fold (0.36 log units) below the measured number; the measured number falls inside the stated range.
By their numbers in this assay, from the lowest: compounds 1, 2, 3 and 4 (each within the scatter of the next, the first and the last beyond it).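

For the compounds shown here, this is the first step that changes one place only: in this assay, methoxycarbonyl in place of methoxymethyl on an aromatic carbon gives a 2.4-fold higher number from compound 1 to compound 4 (0.38 log units; beyond the scatter), a modest step beyond the scatter. Going by these compounds alone, this position is therefore not indifferent to the group it carries, a point the earlier compounds could not show. No evidence on the cause of this step is available.

As far as these compounds go, whether the number follows the carbonyl of methoxycarbonyl or some other feature of the group remains open. An amide or an aminomethyl group at this position would help separate these.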